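Homologation of the oxane amide in compound 3

The compounds below may be only part of what the source reports. "The series", "measured", "known", "first", "only" and "open" are said of these compounds alone.

Within this series the read-out of interest is a physicochemical assay for solubility, read by HPLC, at pH 6.8; on this read-out higher numbers stand for higher solubility and lower numbers for lower solubility. Compound 3 `CC(C)(C)c1cc(NC(=O)[C@@H]2CCCCN2C(=O)C2CCOCC2)no1` gives 48 ug/mL, the highest of the two numbers available. Its nearest neighbour is compound 2 `CC(C)(C)c1cc(NC(=O)[C@@H]2CCCCN2C(=O)C2CCCCC2)no1`, which gives 6.4 ug/mL, and the step of a 7.5-fold higher number from compound 2 to compound 3 (0.88 log units; beyond the scatter). Compound 1 `CC(C)(C)c1cc(NC(=O)[C@@H]2CCCCN2Cc2ccc(Cl)cc2)no1` is reported only as a limit, < 0.1 ug/mL, which is the limit of < 0.1 ug/mL in this assay, at which 1 of the 3 values shown sits. Starting from that limit, the steps of an at least 64-fold higher number from compound 1 to compound 2 (1.80 log units; beyond the scatter) and an at least 480-fold higher number from compound 1 to compound 3 (2.68 log units; beyond the scatter).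

Compound 4 `CC(C)(C)c1cc(NC(=O)[C@@H]2CCCCN2C(=O)CC2CCOCC2)no1` differs from compound 3 by (oxan-4-yl)methyl in place of oxan-4-yl on a carbonyl carbon. Among the measured compounds shown here, none of the measured steps makes this same change. The step closest in place, a 7.5-fold higher number from compound 2 to compound 3 (0.88 log units; beyond the scatter), exchanges one six-membered ring for another on the same carbonyl carbon, whereas here the ring is retained and one carbon is inserted between it and the carbonyl. The two steps from compound 1 replace a benzyl group by an acyl group and are of a different kind altogether. For the measured compounds named here, with no measured step speaking directly to this insertion, the expectation is a step of at most modest size, if any, leaning lower, so that the expected 1.6-fold lower number from compound 3 to compound 4 (0.20 log units; within the scatter) stays near the scatter. Compound 4 is estimated at 30 ug/mL, with a range from 8 ug/mL to 100 ug/mL.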

Compound 4, solubility: 52 ug/mL
Compound 4: the middle estimate sits 1.7-fold (0.24 log units) below what was measured; measured number inside the range.
By their numbers in this assay, from the lowest: compound 2; then compounds 3 and 4 (each within the scatter of the next). At a limit, below all of these: compound 1.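

In this assay the step of a 1.1-fold higher number from compound 3 to compound 4 (0.03 log units; within the scatter) shows that, on a carbonyl carbon whose other neighbours are amide-type nitrogen in a ring, the (oxan-4-yl)methyl group and the oxan-4-yl group cannot be told apart. The one added carbon therefore leaves the standing of the series in this assay intact, and the step of an 8.1-fold higher number from compound 2 to compound 4 (0.91 log units; beyond the scatter) remains beyond the scatter, so the lead over the cyclohexyl amide holds for both groups that carry the ring oxygen. Compound 1 stands only as a limit, so the step of an at least 520-fold higher number from compound 1 to compound 4 (2.71 log units; beyond the scatter) is a bound and not a measured size: the limit of < 0.1 ug/mL in this assay, at which 1 of the 4 values shown sits.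

Still open, on these data alone, is whether a longer chain, such as a 2-(oxan-4-yl)ethyl group on the same carbonyl carbon, would stay level with compound 4 in this assay or fall away from it. Also open, as far as these compounds go, is where a cyclohexylmethyl group at this place would stand, nearer compound 2 or nearer compound 4, and what an amine or a carboxylic acid on the ring would give.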